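Benzylamino in place of 4-methylpiperazin-1-yl on the shared core

The source may hold more compounds than are shown below. What is called first, only, known or untested is meant among the compounds shown, and "the series" means these compounds.

Measured in a functional assay on IMR-32 cells (Homo sapiens) for antiproliferative activity, read by sulforhodamine B assay, with a stated time of 48 h; a lower number here means a stronger inhibitor, a higher number a weaker inhibitor:
- compound 1 `COc1ccc(C[C@@H](O)/C=C/C=C/C(=O)N2CCN(C)CC2)cc1OC`: 18900 nM
- compound 2 `COc1ccc(C[C@@H](O)/C=C/C=C/C(=O)N2CCN(c3ccccc3)CC2)cc1OC`: 9430 nM
- compound 3 `COc1ccc(C[C@@H](O)/C=C/C=C/C(=O)NCc2cc(OC)c(OC)c(OC)c2)cc1OC`: 13400 nM

Compound 1 stands within the usual scatter of both other compounds, so these values set no order among them. The unmeasured compound 4 `COc1ccc(C[C@@H](O)/C=C/C=C/C(=O)NCc2ccccc2)cc1OC` differs from compound 1 by benzylamino in place of 4-methylpiperazin-1-yl on a carbonyl carbon. Within the data shown here, only one measured step bears on the ring of compound 1, a 2.0-fold lower number from compound 1 to compound 2 (0.30 log units; within the scatter), and it stays within the scatter. The closest measured comparison is compound 3, which also has an amide hydrogen and a six-membered aromatic ring of carbon only, at 13400 nM. No change beyond the scatter is therefore expected in this assay. The estimated step, a 1.4-fold lower number from compound 1 to compound 4 (0.13 log units; within the scatter), is correspondingly small. Compound 4 is expected at 14000 nM, with an estimated range from 7500 nM to 25000 nM.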

Compound 4, half-maximal inhibitory concentration: 16600 nM
Estimate against measurement, compound 4: 1.2-fold (0.07 log units) below; the measured number falls inside the stated range.
By their numbers in this assay, from the lowest: compounds 2, 3, 4 and 1 (each within the scatter of the next).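

At this carbonyl carbon, replacing the whole 4-methylpiperazin-1-yl group with benzylamino, which adds an amide hydrogen and an aromatic ring of carbon only, gives no readable change in this assay: a 1.1-fold lower number from compound 1 to compound 4 (0.06 log units; within the scatter). The earlier step altered only the substituent on the ring nitrogen, whereas this one removes the ring itself and still stays within the scatter. No available evidence bears on this result. The compounds shown leave open whether any group here moves the number beyond the scatter, such as a morpholine or a carboxylic acid.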